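The source may report more compounds than this note shows. Statements on the series, on what has been measured and on what is new or still open speak of the compounds shown alone.

Compound 1 `COc1ccc2[nH]c(C(=O)N3CC(=O)N(Cc4ccccc4)[C@@H](CCc4ccccc4)C3)cc2c1`: 0.167 h
Compound 2 `COc1ccc2[nH]c(C(=O)N3CC(=O)N(Cc4ccccc4)[C@@H](COc4ccc(F)cc4)C3)cc2c1`: 0.317 h

In an ADME assay on microsomes from liver (Homo sapiens) for metabolic stability, with a stated time of 30 min, tested at 1 uM (on this read-out higher numbers stand for a longer-lived compound and lower numbers for a shorter-lived compound), compound 2 gives 0.317 h and lies within the scatter of compound 1, so neither stands apart. Compound 3 `COc1ccc2[nH]c(C(=O)N3CC(=O)N(Cc4ccccc4)[C@@H](CN4CC5CC5C4)C3)cc2c1` carries this change: a group of 6 heavy atoms (5 carbon, 1 nitrogen; one three-membered non-aromatic ring of carbon only, one five-membered non-aromatic ring with 1 hetero atom) in place of a group of 8 heavy atoms (6 carbon, 1 oxygen, 1 fluorine; one six-membered aromatic ring of carbon only), on a saturated chain carbon bound to a saturated ring carbon. Within the data shown here, the one measured step at that place, a 1.9-fold higher number from compound 1 to compound 2 (0.28 log units; within the scatter), involved no group like the entering one and offers no direction. No shift beyond the scatter is therefore expected, and the estimated step is a 1.3-fold lower number from compound 2 to compound 3 (0.10 log units; within the scatter). Compound 3 is expected at 0.25 h, with an estimated range of 0.1 h to 0.6 h.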

Compound 3, half-life: 0.35 h
Compound 3: the middle estimate sits 1.4-fold (0.15 log units) below what was measured; low and high end bracket the measured number.
By their numbers in this assay, from the lowest: compounds 1, 2 and 3 (each within the scatter of the next, the first and the last beyond it).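

In this assay the entering group, with its three-membered and five-membered non-aromatic rings, gives a 1.1-fold higher number from compound 2 to compound 3 (0.04 log units; within the scatter) against 4-fluorophenoxy, so this saturated chain carbon tolerates a group without an aromatic ring. Against the benzyl of compound 1, the same group gives a 2.1-fold higher number from compound 1 to compound 3 (0.32 log units; beyond the scatter) and so provides the first modest step beyond the scatter at this place. Nothing available explains either step. Still open, from the compounds shown here alone, is whether a simple dimethylamino group or a carboxylic acid at this place would match compound 3. Also open, going by these compounds, is how an all-carbon ring such as cyclopentyl would compare.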